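The source may report more compounds than this note shows. Statements on the series, on what has been measured and on what is new or still open speak of the compounds shown alone.

Working notes on the series. In a physicochemical assay for permeability, using PAMPA (a lower number here means that the compound crosses the layer more slowly, a higher number that the compound crosses the layer faster), compound 1 (`Cc1ccc(C)c(-c2nc(CN3CCC(C(=O)NCCCN4C[C@H](C)C[C@H](C)C4)CC3)c(C)o2)c1`) carries no result ("not determined" (no result reported)). Among the measured compounds shown here, compound 2 (`Cc1ccccc1-c1nc(CN2CCC(C(=O)NCCCN3[C@H](C)CCC[C@@H]3C)CC2)c(C)o1`) therefore holds the only number (55.4 10^-6 cm/s) and cannot yet be ranked against another compound. The next compound to be measured is compound 3 (`Cc1ccccc1-c1nc(CN2CCC(C(=O)NCCN3C[C@H](C)C[C@H](C)C3)CC2)c(C)o1`). The change (3,5-dimethylpiperidin-1-yl in place of (2,6-dimethylpiperidin-1-yl)methyl on a saturated chain carbon, two bonds along the chain from an amide-type nitrogen) places 3,5-dimethylpiperidin-1-yl in place of (2,6-dimethylpiperidin-1-yl)methyl on a saturated chain carbon, two bonds along the chain from an amide-type nitrogen. For the measured compounds named here, no measured step is available for scale, so the expectation in this assay rests on this structural change and on the single value of compound 2 (55.4 10^-6 cm/s). A modest fall is expected, within the scatter or little beyond it. The estimated change (a 1.6-fold lower number from compound 2 to compound 3 (0.20 log units; within the scatter)) is therefore small. The estimate for compound 3 is 35 10^-6 cm/s with an expected range from 14 10^-6 cm/s to 70 10^-6 cm/s in this read-out.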

Compound 3, apparent permeability: 712 10^-6 cm/s
Estimate against measurement, compound 3: 20-fold (1.31 log units) below; measured number outside the range, above it.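

Among the compounds shown here, putting 3,5-dimethylpiperidin-1-yl in place of (2,6-dimethylpiperidin-1-yl)methyl on a saturated chain carbon, two bonds along the chain from an amide-type nitrogen, gives a 13-fold higher number from compound 2 to compound 3 (1.11 log units; beyond the scatter) in this assay, the first readable step. This position is therefore not silent in this assay, even though the two groups share the counts for hydrogen-bond donors, hydrogen-bond acceptors, net charge and defined stereocentres and differ by 8 heavy atoms against 9. Nothing at hand explains the size of this step.

For the compounds shown here, the single step leaves open whether the number follows the shorter link to the ring or the arrangement of the two methyl groups on it. Going by these compounds, how an unsubstituted piperidin-1-yl or a morpholin-4-yl would behave at this place also remains open.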